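This account rests on a few compounds, and the source may have more. Where it says the series, first, only, none or still open, it means among the compounds named here.

Measured compounds: compound 1 `CC(C)COc1nc(C(C)(C)C)ccc1CNC(=O)C(C)c1ccc(NS(C)(=O)=O)c(F)c1` gives 0.6 nM in an assay on cells for antagonist activity at transient receptor potential cation channel subfamily V member 1 (Homo sapiens), read by FLIPR and calcium flux, with a stated time of 6 min; a higher number here means a weaker inhibitor, a lower number a stronger inhibitor; compound 2 `CC(C(=O)NCc1ccc(C(C)(C)C)cc1N1CCCCC1)c1ccc(NS(C)(=O)=O)c(F)c1` gives 1.9 nM.

Compound 2 holds the higher of the two numbers, with compound 1 at a lower value beyond the scatter. Compound 3 `CC(C(=O)NCc1ccc(C(C)(C)C)cc1OCc1ccc(F)cc1)c1ccc(NS(C)(=O)=O)c(F)c1` differs from compound 2 in one place: (4-fluorobenzyl)oxy in place of piperidin-1-yl on an aromatic carbon. For the measured compounds named here, no step between two measured compounds is available, so the weight of this change is unknown. Compound 1 reaches 0.6 nM with a different group at the same place. Compound 3 is therefore expected to shift a little toward stronger inhibition, by a 1.6-fold lower number from compound 2 to compound 3 (0.20 log units; within the scatter). Compound 3 is estimated at 1.2 nM, ranging from 0.3 nM to 5 nM.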

Compound 3, inhibition constant: 3.8 nM
Compound 3: the middle estimate sits 3.2-fold (0.50 log units) below what was measured; the measured number falls inside the stated range.
By their numbers in this assay, from the lowest: compound 1; then compounds 2 and 3 (each within the scatter of the next).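

For the compounds shown here, on the aromatic carbon ortho to a large group and meta to a tert-butyl group, this assay gives the first reading of a single change, with a 2.0-fold higher number from compound 2 to compound 3 (0.30 log units; within the scatter) for (4-fluorobenzyl)oxy in place of piperidin-1-yl. This position therefore takes either the non-aromatic ring or the larger group with its aromatic ring of carbon only, without a step beyond the scatter. No available evidence bears on this result. The compounds shown leave open how a methoxy group or a morpholine ring would read at this position, and what the fluorine of the benzyl group contributes.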